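This account rests on a few compounds, and the source may have more. Where it says the series, first, only, none or still open, it means among the compounds named here.

Measured so far:
compound 1, `C=CC(=O)Nc1cccc(Nc2ncnc3ccc(-c4ccc(F)nc4)cc23)c1`, > 50000 nM
compound 2, `C=CC(=O)Nc1cccc(Nc2ncnc3ccc(-c4ccc(Cl)nc4)cc23)c1`, 11600 nM

The read-out is a functional assay on Raji cells (Homo sapiens) for inhibition, read by MTT assay, with a stated time of 48 h; a higher number here means a weaker inhibitor, a lower number a stronger inhibitor. For compound 1 the entry > 50000 nM is a limit of the assay and not a number; this is the limit of > 50000 nM in this assay, at which 1 of the 2 values shown sits. Within the data shown here, compound 2 gives 11600 nM in this assay and is therefore the only compound with an actual number. Among the measured compounds shown here, the single measured step, an at least 4.3-fold lower number from compound 1 to compound 2 (0.63 log units; beyond the scatter), shows that exchanging the group on this ring can move the number by a worthwhile amount.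

Compound 3, `C=CC(=O)Nc1cccc(Nc2ncnc3ccc(-c4cnc5ccccc5c4)cc23)c1`, has not been measured. Compared with compound 2 the change is quinolin-3-yl in place of 6-chloropyridin-3-yl on an aromatic carbon. For the measured compounds named here, no measured step swaps a single aromatic ring for a fused one, so the step from compound 2 to compound 3 can only be judged loosely. The step of an at least 4.3-fold lower number from compound 1 to compound 2 (0.63 log units; beyond the scatter) bears on it only in that it shows the exchanged group matters, without fixing a direction. For compound 3 the expected value in this assay is 9000 nM, with a range from 1500 nM to 50000 nM. This estimate means a step of a 1.3-fold lower number from compound 2 to compound 3 (0.11 log units; within the scatter), expected to stay within the scatter.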

Compound 3, half-maximal inhibitory concentration: 3500 nM
Estimate against measurement, compound 3: 2.6-fold (0.41 log units) above; the range from low to high includes it.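

Placing quinolin-3-yl on the aromatic carbon of the shared core in place of 6-chloropyridin-3-yl gives a 3.3-fold lower number from compound 2 to compound 3 (0.52 log units; beyond the scatter) in this assay. This shows that the number at this position can be moved by more than the exchange of one halogen on a single six-membered aromatic ring, since a group that adds a carbon-only aromatic ring also lowers it, and the same position replaced from the fluoro compound gives an at least 14-fold lower number from compound 1 to compound 3 (1.15 log units; beyond the scatter). The entry for compound 1 is a limit and not a number, so the size of that larger step stays open at its far end: the limit of > 50000 nM in this assay, at which 1 of the 3 values shown sits.

The compounds shown do not separate the contribution of the added carbon-only ring from that of the ring nitrogen in quinolin-3-yl, so it remains unclear which part of the group carries the change. They also leave open how a naphthyl group, or an amine or a carboxylic acid carried on the quinolin-3-yl group, would read at this position in this assay.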